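From 2-oxopyrrolidin-1-yl to Trifluoromethyl

The source may report more compounds than this note shows. Statements on the series, on what has been measured and on what is new or still open speak of the compounds shown alone.

In a functional assay on HepG2 cells (Homo sapiens) for inhibition, read by sulforhodamine B assay, with a stated time of 74 h (a higher number here means a weaker inhibitor, a lower number a stronger inhibitor), compound 3 (`O=C1C=CC2(C=C1)OCC(=O)N2S(=O)(=O)c1ccc(N2CCCC2=O)cc1`) gives > 10000 nM, which is a limit and not a number. Compound 1 (`Cc1ccc(S(=O)(=O)N2C(=O)COC23C=CC(=O)C=C3)cc1`) gives > 10000 nM, likewise a limit. The series is small, and (the limit of > 10000 nM in this assay, at which 2 of the 3 values shown sit). Compound 2 (`COc1ccc(S(=O)(=O)N2C(=O)COC23C=CC(=O)C=C3)cc1`) gives a true number, 1620 nM. Compound 4 (`O=C1C=CC2(C=C1)OCC(=O)N2S(=O)(=O)c1ccc(C(F)(F)F)cc1`) carries trifluoromethyl in place of 2-oxopyrrolidin-1-yl on an aromatic carbon. Among the compounds with values here, no measured step involves trifluoromethyl, so the nearest guides are an at least 6.1-fold lower number from compound 1 to compound 2 (0.79 log units; beyond the scatter) and an at least 6.1-fold higher number from compound 2 to compound 3 (0.79 log units; beyond the scatter), while a step that the two limits leave unreadable from compound 1 to compound 3. Both readable steps turn on the methoxy of compound 2, so only a modest move is expected. The expected step, towards a lower number, is an at least 1.6-fold lower number from compound 3 to compound 4 (0.22 log units; that floor lies within the scatter). Compound 4 is estimated at 6000 nM, within an expected range of 1500 nM to 20000 nM.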

Compound 4, half-maximal inhibitory concentration: 750 nM
The estimate for compound 4 lay 8.0-fold (0.90 log units) above the measured number, outside the stated range (below it).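

Compound 4 shows that this place on the aromatic ring can carry trifluoromethyl and give the strongest inhibitor of the four in this assay, with a 2.2-fold lower number from compound 2 to compound 4 (0.33 log units; beyond the scatter). The gaps to the other two groups are wider, with an at least 13-fold lower number from compound 3 to compound 4 (1.12 log units; beyond the scatter) and an at least 13-fold lower number from compound 1 to compound 4 (1.12 log units; beyond the scatter). Both of these steps start from a limit and not a number: the limit of > 10000 nM in this assay, at which 2 of the 4 values shown sit.

The compounds shown leave open how a nitrile, a chlorine or an amine would read at this place. They also leave open whether trifluoromethyl gives the same gain on a changed core.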